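Aryl amide series: pyrrolidinyl carbonyl replacing chloropyridinyl carbonyl

The source may hold more compounds than are shown below. What is called first, only, known or untested is meant among the compounds shown, and "the series" means these compounds.

Three compounds of the shared core have numbers in an assay on U2OS cells for inhibition of secreted frizzled-related protein 1 (Homo sapiens), read by a luciferase reporter, with a stated time of 18 h; on this read-out higher numbers stand for an effect only at larger amounts of compound and lower numbers for an effect already at smaller amounts. Compound 1 `O=C(c1cccc(Cl)c1)N1CCC(NS(=O)(=O)c2cc(S(=O)(=O)c3ccccc3)ccc2C(F)(F)F)CC1` gives 870 nM. Compound 2 `O=C(c1ccc(Cl)nc1)N1CCC(NS(=O)(=O)c2cc(S(=O)(=O)c3ccccc3)ccc2C(F)(F)F)CC1` gives 140 nM, the lowest of the three numbers. Compound 3 `O=C(O)c1ccc(N2CCC(NS(=O)(=O)c3cc(S(=O)(=O)c4ccccc4)ccc3C(F)(F)F)CC2)cc1` gives 230 nM. The step of a 6.2-fold lower number from compound 1 to compound 2 (0.79 log units; beyond the scatter) is beyond the scatter; the step of a 1.6-fold higher number from compound 2 to compound 3 (0.22 log units; within the scatter) is within it, so compound 2 and compound 3 cannot be ordered against each other, while compound 1 sits clearly apart from both.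

Compound 4 `O=C([C@@H]1CCNC1)N1CCC(NS(=O)(=O)c2cc(S(=O)(=O)c3ccccc3)ccc2C(F)(F)F)CC1` is not yet measured in this assay. Its difference from compound 2 is pyrrolidin-3-yl in place of 6-chloropyridin-3-yl on a carbonyl carbon.

Of the measured steps, only a 6.2-fold lower number from compound 1 to compound 2 (0.79 log units; beyond the scatter) changes the group on the carbonyl carbon, and there one six-membered aromatic ring replaces another; a 1.6-fold higher number from compound 2 to compound 3 (0.22 log units; within the scatter) and a 3.8-fold lower number from compound 1 to compound 3 (0.58 log units; beyond the scatter) remove the carbonyl altogether. For the measured compounds named here, no measured step replaces the aromatic ring on the carbonyl carbon by a non-aromatic ring, so the bearing of these steps on compound 4 is loose. The data show the group on the carbonyl carbon matters within the scatter's reach or beyond it, in either direction. A moderately higher number is expected for compound 4, with the step from compound 2 estimated as a 3.6-fold higher number from compound 2 to compound 4 (0.55 log units; beyond the scatter), and a wide range. Compound 4 is estimated at 500 nM, between 120 nM and 2500 nM.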

Compound 4, half-maximal effective concentration: 380 nM
Compound 4: middle estimate off by 1.3-fold (0.12 log units), on the high side; low and high end bracket the measured number.
By their numbers in this assay, from the lowest: compounds 2, 3 and 4 (each within the scatter of the next, the first and the last beyond it); then compound 1.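

In this assay the carbonyl carbon carries a non-aromatic ring with a measurable effect still in the same range: pyrrolidin-3-yl, a five-membered ring with a hydrogen-bond donor, gives a 2.7-fold higher number from compound 2 to compound 4 (0.43 log units; beyond the scatter) and so stands modestly behind 6-chloropyridin-3-yl. The same replacement gives a 2.3-fold lower number from compound 1 to compound 4 (0.36 log units; beyond the scatter) when set against 3-chlorophenyl, so at this position the non-aromatic ring falls between two six-membered aromatic rings, and no simple rule that aromatic rings give lower numbers holds, with compound 1 going against it. The step of a 1.7-fold higher number from compound 3 to compound 4 (0.22 log units; within the scatter) lies within the scatter, so the (pyrrolidin-3-yl)carbonyl and 4-carboxyphenyl groups on the amine nitrogen in a ring cannot be ordered against each other.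

Open, from the compounds shown here alone, is how a cyclopentyl group on the carbonyl carbon would read, which would separate the contribution of the ring nitrogen from that of the ring itself. Also open, going by these compounds, are the opposite stereoisomer at the defined stereocentre and a methyl group on the nitrogen of the pyrrolidine. Nothing available here accounts for the size or direction of these steps.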